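The compounds below may be only part of what the source reports. "The series", "measured", "known", "first", "only" and "open" are said of these compounds alone.

Series notes. Compound 1 `O=C(Nc1cccc(Cl)c1)c1ccccc1O` carries the shared core with a free hydroxyl. In an assay for inhibition of HSP60/HSP10 (Homo sapiens), with a stated time of 60 min (on this read-out higher numbers stand for weaker inhibition and lower numbers for stronger inhibition), compound 1 reaches only the assay limit, > 100000 nM. Compound 2 `COc1ccccc1C(=O)Nc1cccc(Cl)c1` differs by a methyl in place of hydrogen on an oxygen on an aromatic ring. In this assay compound 2 likewise reaches only the limit, > 100000 nM. The step that the two limits leave unreadable from compound 1 to compound 2 cannot be read because both values sit at the limit of > 100000 nM in this assay, at which 2 of the 2 values shown sit. Compound 3 `COc1c(Br)cccc1C(=O)Nc1cccc(Cl)c1` adds (bromo in place of hydrogen on an aromatic carbon). For the measured compounds named here, no measured step bears on this change, and compound 2 stands at a limit, so no direction can be read. Compound 3 is therefore expected to stay near the limit, at an estimated 150000 nM (range 30000 nM to 1000000 nM). The expected step that the limit leaves unreadable from compound 2 to compound 3 is essentially none.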

Compound 3, half-maximal inhibitory concentration: > 100000 nM
Compound 3 was reported as a limit; the forecaster's own chance of this, stated with the estimate: 85%; the middle value lies beyond the limit too.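

No step from compound 2 to compound 3 can be read in this assay, as both values are limits: the limit of > 100000 nM in this assay, at which 3 of the 3 values shown sit.

The compounds shown leave open whether any change to the shared core gives a measurable value in this assay.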